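Lipophilicity notes on a phenoxyacetic acid series

This account rests on a few compounds, and the source may have more. Where it says the series, first, only, none or still open, it means among the compounds named here.

Compound 1 `Cc1ccccc1-c1cccc(CNc2ccc(OCC(=O)O)c(F)c2)c1` and compound 2 `COc1ccccc1-c1cccc(CNc2ccc(OCC(=O)O)c(F)c2)c1` share a core and differ only in the aryl group borne by the second ring. In a physicochemical assay for lipophilicity, read by HPLC, in phosphate buffer, measured as octanol-water partition, at pH 7.4, tested at 100 uM (on this read-out higher numbers stand for higher lipophilicity and lower numbers for lower lipophilicity), compound 1 gives 2.41. Compound 2 in this assay gives "not determined" (no result reported), so compound 2 stands on no number in this read-out, and the two compounds cannot be compared on what is shown. Compound 3 `CCOc1ccc(-c2cccc(CNc3ccc(OCC(=O)O)c(F)c3)c2)c(C)c1` is the next member to be run. It differs from compound 2 as follows: 4-ethoxy-2-methylphenyl in place of 2-methoxyphenyl on an aromatic carbon. For the measured compounds named here, no measured step exists between compound 2 and compound 3, and no pair of measured compounds brackets this change. The step is nevertheless expected to raise this assay beyond the usual scatter, since compound 3 carries both the ethoxy and the methyl. Taking compound 1 with its 2.41 as the only anchor, compound 3 is estimated at 2.9 in this assay, within 2.4 to 3.4.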

Compound 3, distribution coefficient: 2.83
Beside the measured number, compound 3's estimate is 0.07 log units above it, within the range that was stated.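

In this assay the series now holds a readable step: ethoxy in place of hydrogen on an aromatic carbon, which turns the 2-methylphenyl of compound 1 into the 4-ethoxy-2-methylphenyl of compound 3, goes with a number 0.42 log units higher from compound 1 to compound 3 (beyond the scatter). This place on the ring therefore carries a substitution with a modest shift beyond the usual scatter, where a single value previously stood alone. Nothing measured in the data shown accounts for the shift.

The step between compound 2 and compound 3 cannot be read, as compound 2 has no number. On these data alone, whether a longer chain such as butoxy, or an amine, at this same place would shift the value in the same direction or to a similar size remains open.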